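The source may report more compounds than this note shows. Statements on the series, on what has been measured and on what is new or still open speak of the compounds shown alone.

Working notes on the series. In a functional assay on L5178Y cells (Mus musculus) for inhibition, read by MTT assay, with a stated time of 24 h (on this read-out lower numbers stand for stronger inhibition and higher numbers for weaker inhibition), compound 1 `O=C(Cc1c[nH]c2ccccc12)N/N=C1\C[C@@H](c2ccc(O)cc2)Oc2cc(O)cc(O)c21` gives only a limit (>= 11300 nM). Compound 2 `COc1cc(O)c2c(c1)O[C@H](c1ccc(O)cc1)C/C2=N\NC(=O)c1ccco1` also gives only a limit (>= 11300 nM). Compound 3 `COc1cc(O)c2c(c1)O[C@H](c1ccc(OCC3CO3)cc1)CC2=O` likewise gives only a limit (>= 11300 nM). Compound 3 therefore stands with the other two at the limit of >= 11300 nM in this assay, at which 3 of the 3 values shown sit, and cannot be ranked against them.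

Compound 4 `COc1cc(O)c2c(c1)O[C@H](c1ccc(OCC(O)CN3CCCCC3)cc1)CC2=O` carries 1-hydroxy-2-(piperidin-1-yl)ethyl in place of oxiran-2-yl on a saturated chain carbon bound to an oxygen on an aromatic ring.

No measured step sizes this change in this assay. A moderate move toward stronger inhibition is expected, estimated as an at least 1.6-fold lower number from compound 3 to compound 4 (0.20 log units; that floor lies within the scatter) for now. For compound 4 the estimated value is 7000 nM with an expected range from 2000 nM to 25000 nM (a reading at the limit remains possible).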

Compound 4, half-maximal inhibitory concentration: 9300 nM
Compound 4: the middle estimate sits 1.3-fold (0.12 log units) below what was measured, within the range that was stated.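

In this assay, oxiran-2-yl giving way to 1-hydroxy-2-(piperidin-1-yl)ethyl on a saturated chain carbon bound to an oxygen on an aromatic ring gives an at least 1.2-fold lower number from compound 3 to compound 4 (0.08 log units; that floor lies within the scatter). Compound 4 is the only compound shown that reads as a number, while compound 1, compound 2 and compound 3 remain at a limit: the limit of >= 11300 nM in this assay, at which 3 of the 4 values shown sit.

The true size of the step cannot be read beyond that floor. The compounds shown leave open whether the hydroxyl or the piperidine ring goes with this reading, and how a morpholine or an open-chain dimethylamine would read in place of the piperidine.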